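This account rests on a few compounds, and the source may have more. Where it says the series, first, only, none or still open, it means among the compounds named here.

In a physicochemical assay for solubility, read by spectrophotometry, in phosphate buffer, with a stated time of 18 h, at pH 7.4 (on this read-out lower numbers stand for lower solubility and higher numbers for higher solubility), compound 1 (`CCc1ccc(-c2nc3c(c(C)nn3-c3ccccc3)c(-c3ccccc3Cl)c2C#N)cc1`) gives 1700 nM and compound 2 (`CCc1ccc(-c2nc3c(c(C)nn3-c3ccccc3)c(-c3ccccc3S(C)(=O)=O)c2C#N)cc1`) gives 2200 nM as its measured value, level with compound 1 within the scatter. Compound 3 (`CCc1ccc(-c2nc3c(c(C)nn3-c3ccccc3)c(-c3ccccc3C(=O)O)c2C#N)cc1`) carries carboxy in place of methylsulfonyl on an aromatic carbon. For the measured compounds named here, the only measured step is a 1.3-fold higher number from compound 1 to compound 2 (0.11 log units; within the scatter) for methylsulfonyl in place of chloro. It involves no carboxy and offers little guidance. An upward move beyond the scatter is nevertheless expected, a judgement the measured compounds cannot confirm, and the estimated step in this assay is a 9.1-fold higher number from compound 2 to compound 3 (0.96 log units; beyond the scatter) on this reasoning. Compound 3 is estimated at 20000 nM with an expected range of 5000 nM to 80000 nM for now.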

Compound 3, solubility: 33000 nM
The estimate for compound 3 lay 1.7-fold (0.22 log units) below the measured number; low and high end bracket the measured number.
By their numbers in this assay, from the lowest: compounds 1 and 2 (each within the scatter of the next); then compound 3.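

In this assay, the group on this aromatic carbon can matter a great deal. Carboxy gives a large rise against methylsulfonyl (a 15-fold higher number from compound 2 to compound 3 (1.18 log units; beyond the scatter)) and against chloro (a 19-fold higher number from compound 1 to compound 3 (1.29 log units; beyond the scatter)), whereas the earlier swap of chloro for methylsulfonyl stayed within the scatter. So not every replacement at this position leaves the number level, and compound 3 stands clear of both earlier compounds.

Nothing available here bears on what lies behind this rise. From the compounds shown here alone, whether an amide or an amine on the same carbon would give a similar rise remains open.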